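This account rests on a few compounds, and the source may have more. Where it says the series, first, only, none or still open, it means among the compounds named here.

Compound 1 `COCCn1nc(C(=O)N[C@H]2COc3ccccc3N(C)C2=S)nc1Cc1ccccc1` gives in a toxicity assay on HT-29 cells (Homo sapiens) for cytotoxicity (on this read-out higher numbers stand for lower toxicity in this test and lower numbers for higher toxicity in this test), only a limit, > 100000 nM. Compound 2 `CN1C(=S)[C@@H](NC(=O)c2nc(Cc3ccccc3)n(CCCC(F)(F)F)n2)COc2ccccc21` likewise gives in this assay only a limit, > 100000 nM. Between them lies a step that the two limits leave unreadable from compound 1 to compound 2. Compound 3 `CN1C(=S)[C@@H](NC(=O)c2nc(Cc3ccccc3)n(CC3COC3)n2)COc2ccccc21` is not yet measured; it differs from compound 2 by oxetan-3-yl in place of 3,3,3-trifluoropropyl on a saturated chain carbon bound to an aromatic nitrogen. Among the compounds with values here, the single measured step reaching compound 2 is unreadable, and both values shown sit at the limit of > 100000 nM in this assay, at which 2 of the 2 values shown sit, so in this assay no step of readable size is expected here either. For compound 3 the expected step is a number no higher from compound 2 to compound 3 (the limit leaves the size open). The estimate for compound 3 is 100000 nM, between 40000 nM and 200000 nM, most likely reported again as a limit.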

Compound 3, half-maximal cytotoxic concentration: > 100000 nM
Compound 3 gave a limit, no number (the forecaster's own chance of this, stated with the estimate: 85%); the middle value lies on the limit itself.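

No step among compound 1, compound 2 and compound 3 can be read in this assay, since all three values are limits: the limit of > 100000 nM in this assay, at which 3 of the 3 values shown sit.

The compounds shown leave open whether oxetan-3-yl and 3,3,3-trifluoropropyl differ at all in this assay.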